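Lengthening the side chain of a chlorinated compound

The compounds below may be only part of what the source reports. "The series", "measured", "known", "first", "only" and "open" are said of these compounds alone.

In a functional assay on HeLa cells (Homo sapiens) for antiproliferative activity, read by MTT assay, with a stated time of 48 h (a lower number here means a stronger inhibitor, a higher number a weaker inhibitor), compound 1 `CCN(CC)CCn1c(N)c(-c2nc3ccccc3[nH]2)c2nc(C#N)c(C#N)nc21` gives 11600 nM. Compound 2 `CCN(CC)CCn1c(N)c(-c2nc3ccccc3n2C)c2nc(C#N)c(C#N)nc21` gives > 50000 nM, which is a limit and not a number. Compound 3 `CCN(CC)CCn1c(N)c(-c2nc3cc(Cl)ccc3[nH]2)c2nc(C#N)c(C#N)nc21` gives > 50000 nM, which is also a limit. Compound 3 therefore stands at the limit of > 50000 nM in this assay, at which 2 of the 3 values shown sit.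

Compound 4 `CCN(CC)CCCCn1c(N)c(-c2nc3cc(Cl)ccc3[nH]2)c2nc(C#N)c(C#N)nc21` differs from it only in the side chain, where a 4-(diethylamino)butyl group replaces a 2-(diethylamino)ethyl group: 2-(diethylamino)ethyl in place of diethylamino on a saturated chain carbon, two bonds along the chain from an aromatic nitrogen. The measured steps, an at least 4.3-fold higher number from compound 1 to compound 3 (0.63 log units; beyond the scatter) for chloro in place of hydrogen and an at least 4.3-fold higher number from compound 1 to compound 2 (0.63 log units; beyond the scatter) for methyl in place of hydrogen, lie elsewhere on the molecule and set no size for this change. Only a small move toward a lower number is expected, an at least 1.4-fold lower number from compound 3 to compound 4 (0.15 log units; that floor lies within the scatter). The estimate for compound 4 is 35000 nM, with an expected range of 10000 nM to 70000 nM.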

Compound 4, half-maximal inhibitory concentration: 3640 nM
For compound 4 the middle estimate is 9.6-fold (0.98 log units) above the measured one; measured number outside the range, below it.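

In this assay, with the chloro group kept, replacing the 2-(diethylamino)ethyl group by the 4-(diethylamino)butyl group gives an at least 13-fold lower number from compound 3 to compound 4 (1.13 log units; beyond the scatter). Compound 3 gives only a limit, not a number: the limit of > 50000 nM in this assay, at which 2 of the 4 values shown sit. The earlier steps shown all led to that limit, whereas this one shows that the side chain alone can bring a chlorinated compound back to a measurable value.

As far as these compounds go, it remains open whether the 4-(diethylamino)butyl chain would do the same for compound 1, which has no chloro group. A still longer chain, or a piperidine in place of diethylamino, is also untested among the compounds shown.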